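Methyl to Methoxy: What to Expect for Compound 3

A few compounds are considered here, and "the series" means these few. Any claim that something is new, unique, unknown or untested is made for them only; others in the source may bear on it.

Compound 1, `Cc1ccc(NC(=S)OCCNC(=O)c2cccnc2)cc1`, was examined in an ADME assay for pharmacokinetics, in phosphate buffer, tested at 60 uM (a lower number here means that the compound disappears faster, a higher number that the compound lasts longer), where compound 1 gives 0.015 h. For the measured compounds named here, the only other compound measured in this assay is compound 2, `CC(C)(Oc1ccc(Cl)cc1)C(=O)NCCOC(=S)Nc1ccc([N+](=O)[O-])cc1Cl`, and in this assay compound 2 gives 0.0283 h. The two numbers lie within the usual scatter of each other, so nothing separates compound 1 from compound 2 on this read-out; both describe compounds that disappear quickly under these conditions. Going by the values given here, no pair of measured compounds differing in a single place is available, so no measured step guides the next comparison.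

Compound 3, `COc1ccc(NC(=S)OCCNC(=O)c2cccnc2)cc1`, differs from compound 1 in one place: methoxy in place of methyl on an aromatic carbon. The rest of the molecule is unchanged.

Among the compounds with values here, with no measured step of this kind to draw on, the expectation is that the change brings no shift beyond the scatter, and the step from compound 1 to compound 3 in this assay is estimated at a 1.2-fold higher number from compound 1 to compound 3 (0.08 log units; within the scatter). Compound 3 is therefore expected to give 0.018 h in this assay, with a range from 0.007 h to 0.045 h.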

Compound 3, half-life: 0.0133 h
Compound 3: the middle estimate sits 1.4-fold (0.13 log units) above what was measured, within the range that was stated.
By their numbers in this assay, from the lowest: compounds 3, 1 and 2 (each within the scatter of the next, the first and the last beyond it).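

For the compounds shown here, this is the first measured step at this position: in this assay, methoxy in place of methyl on an aromatic carbon, para to a large group, gives a 1.1-fold lower number from compound 1 to compound 3 (0.05 log units; within the scatter), so this single exchange does not separate the two compounds on this read-out. The entering methoxy carries 1 hydrogen-bond acceptor where the methyl carries none, yet compound 3 stays level with compound 1, and both remain compounds that disappear quickly in this buffer. No measurement available here bears on why the half-life responds so little to this change.

What the compounds shown leave open is whether any group at this position can move the half-life beyond the scatter, for instance an amine, a carboxylic acid or a longer alkoxy chain in place of the methoxy. One step at one position also leaves open whether methoxy in place of methyl would behave the same way elsewhere on the core of compound 1, or whether a change away from this aromatic ring would matter more.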